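Dimethyl variant of the quinoxaline dioxide amide series

The compounds below may be only part of what the source reports. "The series", "measured", "known", "first", "only" and "open" are said of these compounds alone.

Measured compounds:
compound 1 `CC(=O)Oc1ccccc1C(=O)Nc1c(C#N)[n+]([O-])c2cc(Cl)ccc2[n+]1[O-]` — in an ADME assay on cells (Peritoneal macrophage cell, Mus musculus) for cytotoxicity, read by trypan blue exclusion, with a stated time of 48 h (on this read-out higher numbers stand for lower toxicity in this test and lower numbers for higher toxicity in this test), compound 1 gives "not determined" (no result reported)
compound 2 `CC(=O)Oc1ccccc1C(=O)Nc1c(C#N)[n+]([O-])c2cc(C)ccc2[n+]1[O-]` — 21700 nM

For the measured compounds named here, compound 2 holds the only number in this assay; compound 1 has no result, so no step between measured compounds is available. Compound 3 `CC(=O)Oc1ccccc1C(=O)Nc1c(C#N)[n+]([O-])c2cc(C)c(C)cc2[n+]1[O-]` differs from compound 2 by methyl in place of hydrogen on an aromatic carbon. Going by the values given here, with no comparable step to draw on, the change is expected to fall within the usual scatter, perhaps leaning slightly toward higher toxicity; the expected step is a 1.3-fold lower number from compound 2 to compound 3 (0.11 log units; within the scatter). Compound 3 is therefore estimated at 17000 nM, with a range from 6000 nM to 45000 nM.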

Compound 3, half-maximal cytotoxic concentration: 12500 nM
Compound 3: middle estimate off by 1.4-fold (0.13 log units), on the high side, within the range that was stated.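

In this assay, methyl in place of hydrogen on an aromatic carbon, ortho to a methyl group, gives a 1.7-fold lower number from compound 2 to compound 3 (0.24 log units; within the scatter), so this second methyl on the ring carries no step beyond the scatter. For the compounds shown here, this is the first step that can be read, and it covers only this one change at this one position. No data shown here bear on what lies behind the size of this step. Open, on these data alone, is whether an amine, a carboxylic acid or a longer chain at this position would give a step beyond the scatter. Also open, as far as these compounds go, is how a chlorine compares with a methyl, as compound 1 gives "not determined" (no result reported).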